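The source may report more compounds than this note shows. Statements on the series, on what has been measured and on what is new or still open speak of the compounds shown alone.

In a functional assay on the whole organism for inhibition, with Rattus norvegicus as the target, read by cytopathic effect and paw edema, at a dose of 100 mg/kg by the oral route (on this read-out lower numbers stand for less inhibition and higher numbers for more inhibition at the one dose given (going by the name of the read-out)), compound 1 `Cc1cccc(NC(=O)c2c(O)c3cccnc3n(-c3ccccc3)c2=O)c1` gives 4.5%, while compound 2 `O=C(Nc1cccnc1)c1c(O)c2cccnc2n(-c2ccccc2)c1=O` gives 30.8%, the higher of the two numbers measured. The one step shown, a number 26.3 percentage points higher from compound 1 to compound 2 (beyond the scatter), moves from a carbon ring to a ring holding one nitrogen. Compound 3 `O=C(Nc1ccncc1)c1c(O)c2cccnc2n(-c2ccccc2)c1=O` keeps that nitrogen-holding ring but shifts where the nitrogen sits (pyridin-4-yl in place of pyridin-3-yl on an amide-type nitrogen). For the measured compounds named here, no measured step bears on such a shift within the same ring, so the expected change is small, a number 3.8 percentage points lower from compound 2 to compound 3 (within the scatter), but with a wide uncertainty. Compound 3 is therefore expected to give 27%, within a range from 5% to 50%.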

Compound 3, a percentage reported as inhibition, in the whole organism at one dose (the size of the read-out at that dose, not a potency): 24.3%
Estimate against measurement, compound 3: 2.7 percentage points above, within the range that was stated.
By their numbers in this assay, from the lowest: compound 1; then compounds 3 and 2 (each within the scatter of the next).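

In this assay, moving the ring nitrogen from pyridin-3-yl to pyridin-4-yl gives a number 6.5 percentage points lower from compound 2 to compound 3 (within the scatter), so the two placings cannot be told apart on the amide-type nitrogen. The pyridin-4-yl ring also stands clear of 3-methylphenyl, with a number 19.8 percentage points higher from compound 1 to compound 3 (beyond the scatter), so among these compounds the rise does not depend on one placing of the ring nitrogen. Nothing available explains why these rings give higher numbers than 3-methylphenyl.

Still open, from the compounds shown here alone, is how pyridin-2-yl would read at this position, and whether a saturated ring such as piperidin-4-yl would keep the number.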